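Dimethoxyphenyl isomers at the limit of the assay

The compounds below may be only part of what the source reports. "The series", "measured", "known", "first", "only" and "open" are said of these compounds alone.

In a functional assay on DU-145 cells (Homo sapiens) for cytotoxicity, read by MTT assay, with a stated time of 48 h (on this read-out higher numbers stand for weaker inhibition and lower numbers for stronger inhibition), compound 1 `COc1ccc(/C=C/C(=O)/C=C/c2cc3ccccc3nc2Oc2ccccc2)cc1OC` gives only a limit > 10000 nM and no number. Compound 2 `COc1ccc(/C=C/C(=O)/C=C/c2cc3ccccc3nc2Oc2ccc(Br)cc2)cc1` likewise gives only a limit > 10000 nM and no number. Compound 3 `COc1ccc(OC)c(/C=C/C(=O)/C=C/c2cc3ccccc3nc2Oc2ccc(Br)cc2)c1` also stands at a limit > 10000 nM and so has no number to start from. Going by the values given here, the series so far shows the limit of > 10000 nM in this assay, at which 3 of the 3 values shown sit, and gives no ranking. Compound 4 `COc1ccc(/C=C/C(=O)/C=C/c2cc3ccccc3nc2Oc2ccc(Br)cc2)cc1OC` differs from compound 3 by 3,4-dimethoxyphenyl in place of 2,5-dimethoxyphenyl on a double-bonded chain carbon bound to a double-bonded chain carbon with 3,4-dimethoxyphenyl in place of 2,5-dimethoxyphenyl on a double-bonded chain carbon bound to a double-bonded chain carbon. Among the compounds with values here, the one measured step that the two limits leave unreadable from compound 2 to compound 3 offers no size to carry over. The expected step that the limit leaves unreadable from compound 3 to compound 4 is small and has no firm direction in this assay so a reading near the limit is expected. The estimate for compound 4 is 12000 nM with an expected range from 5000 nM to 30000 nM and a report of a limit alone remains likely.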

Compound 4, half-maximal inhibitory concentration: > 10000 nM
Compound 4 was reported as a limit; the forecaster's own chance of this, stated with the estimate: 70%; the middle value is on the limit's open side.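

No step can be read among compound 1, compound 2, compound 3 and compound 4, because every value is a limit: the limit of > 10000 nM in this assay, at which 4 of the 4 values shown sit.

On these data alone, whether the dimethoxyphenyl isomers, the added methoxy or the bromo change potency at all in this assay stays open.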